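Cyclobutane carboxamide series: pyrimidinyl to pyridinyl swap

A few compounds are considered here, and "the series" means these few. Any claim that something is new, unique, unknown or untested is made for them only; others in the source may bear on it.

Measured so far:
compound 1, `O=C(Nc1ccc(Cl)cc1)C1(c2ccc3c(n2)CCN3c2ccccn2)CCC1`: 2.3 nM
compound 2, `Cc1nccc(N2CCc3nc(C4(C(=O)Nc5ccc(Cl)cc5)CCC4)ccc32)n1`: 12.5 nM
compound 3, `Cc1nccc(N2CCc3cc(C4(C(=O)Nc5ccc(F)cc5)CCC4)ccc32)n1`: 5.2 nM

In an assay on HeLa cells for inhibition of Indoleamine 2,3-dioxygenase 1 (Homo sapiens) (a higher number here means a weaker inhibitor, a lower number a stronger inhibitor), compound 1 gives 2.3 nM. Compound 2 `Cc1nccc(N2CCc3nc(C4(C(=O)Nc5ccc(Cl)cc5)CCC4)ccc32)n1` gives 12.5 nM in this assay. Among the compounds with values here, the step of a 5.4-fold lower number from compound 2 to compound 1 (0.74 log units; beyond the scatter) is the one change measured so far: pyridin-2-yl in place of 2-methylpyrimidin-4-yl on a nitrogen on an aromatic ring in a ring. Compound 3 `Cc1nccc(N2CCc3cc(C4(C(=O)Nc5ccc(F)cc5)CCC4)ccc32)n1` gives 5.2 nM in this assay; its number stands between those of compound 1 and compound 2. Compound 3 and compound 2 differ in more than one place, and the difference between the two cores is not broken down here.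

Compound 4 `O=C(Nc1ccc(F)cc1)C1(c2ccc3c(c2)CCN3c2ccccn2)CCC1` is not yet measured. It is made from compound 3 by the same change: pyridin-2-yl in place of 2-methylpyrimidin-4-yl on a nitrogen on an aromatic ring in a ring. The place is the same in both words for words, so the change is the same kind of change, made on a core that is not the same as that of compound 2. If the step repeats on the core of compound 3, a step of about a 4.3-fold lower number from compound 3 to compound 4 (0.64 log units; beyond the scatter) is expected, resting on a 5.4-fold lower number from compound 2 to compound 1 (0.74 log units; beyond the scatter) with compound 3 at 5.2 nM as the starting point. The estimate for compound 4 in this assay is 1.2 nM, expected between 0.4 nM and 4 nM.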

Compound 4, half-maximal inhibitory concentration: 3.1 nM
Compound 4: middle estimate off by 2.6-fold (0.41 log units), on the low side, and the stated range covers the measured number.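

On the core of compound 3, pyridin-2-yl in place of 2-methylpyrimidin-4-yl gives a 1.7-fold lower number from compound 3 to compound 4 (0.22 log units; within the scatter) in this assay, so no effect of the change can be claimed on this core. The change therefore does not carry over at a fixed size from one core to the other: the same change on two cores in this assay, a 5.4-fold lower number (0.74 log units; beyond the scatter) from compound 2 to compound 1 and a 1.7-fold lower number (0.22 log units; within the scatter) from compound 3 to compound 4, 3.2-fold (0.51 log units) apart, beyond the scatter of two such steps

This does not show that the core alone sets the size of the step: compound 1 and compound 2 carry chlorine as the halogen of the amide's aryl group, whereas compound 3 and compound 4 carry fluorine, and these two pairs cannot separate that difference from the difference in core.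

Open, as far as these compounds go, is whether the step on the core of compound 3 would stay the same with chlorine in place of fluorine, and what size it would take on a third core. Also open, from the compounds shown here alone, is how other groups on the same nitrogen, such as a phenyl or an acetyl group, would read in this assay.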